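A few compounds are considered here, and "the series" means these few. Any claim that something is new, unique, unknown or untested is made for them only; others in the source may bear on it.

Measured compounds in the series so far:

Compound 1, `C#CCCCn1c(Cc2cc(OC)c(OC)c(OC)c2)nc2c(N)ncnc21`: 45900 nM
Compound 2, `COc1cc(Cc2nc3c(N)ncnc3n2CCCC#CCNCCCCCCCCNCC#CCCCn2c(Cc3cc(OC)c(OC)c(OC)c3)nc3c(N)ncnc32)cc(OC)c1OC`: 30600 nM
Compound 3, `COc1cc(Cc2nc3c(N)ncnc3n2CCCC#CCNCCCCCCCCCCCCN)cc(OC)c1OC`: 55100 nM

Working notes. All three measured compounds share the same trimethoxybenzyl-bearing core and a butynyl chain on the core nitrogen, and all were tested in a functional assay on MCF7 cells (Homo sapiens) for cytotoxicity, with a stated time of 24 h; on this read-out higher numbers stand for weaker inhibition and lower numbers for stronger inhibition. Compound 1 carries the shortest chain, with a free terminal alkyne. Its number in this assay sits between those of its two neighbours, and neither gap is a real one: compound 3 gives a number close to it, and compound 2 gives a number also close to it, both spreads lying inside the usual scatter of this read-out. For the measured compounds named here, no step between measured compounds rests on a single change, so nothing in the set isolates what the chain end contributes.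

Compound 4, `COc1cc(Cc2nc3c(N)ncnc3n2CCCC#CCO)cc(OC)c1OC`, has not been measured. It differs from compound 1 in one place:

hydroxymethyl in place of hydrogen on a triple-bonded carbon

The change is a small one at the far end of the chain, and the three measured compounds, which vary much more at that position, give numbers that cannot be told apart. The step from compound 1 to compound 4 is therefore expected to be small, a 1.0-fold lower number from compound 1 to compound 4 (0.01 log units; within the scatter), with no direction claimed beyond the scatter. Compound 4 is estimated at 45000 nM, with a range from 20000 nM to 100000 nM.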

Compound 4, half-maximal inhibitory concentration: > 100000 nM
Compound 4 ended at the assay's limit; the forecaster's own chance of this, stated with the estimate: 20%; middle value at least 2.2-fold (0.34 log units) away from the limit.
By their numbers in this assay, from the lowest: compounds 2, 1 and 3 (each within the scatter of the next). At a limit, above all of these: compound 4.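

Compound 4 gives > 100000 nM in this assay, and this value is a limit of the assay, not a number. Hydroxymethyl in place of hydrogen on a triple-bonded carbon gives an at least 2.1-fold higher number from compound 1 to compound 4 (0.33 log units; beyond the scatter), the first step in the series that rests on one change and the first printed as beyond the scatter, so this end of the chain is not indifferent to substitution, as the closely grouped values of the earlier compounds might have suggested, and the direction here is towards weaker inhibition. Going by these compounds, the step fixes a direction and a minimum size, while its full size remains unknown: the limit of > 100000 nM in this assay, at which 1 of the 4 values shown sits.

The compounds shown do not separate the contribution of the added carbon from that of the hydroxyl, and a plain methyl group on the same triple-bonded carbon would draw that line. Nor do they show whether the step is particular to hydroxymethyl or extends to other small groups at this place, such as an aminomethyl group or a carboxylic acid, or to a longer chain ending in a hydroxyl.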